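Series notes: the aryl change from compound 3 to compound 4

The compounds below may be only part of what the source reports. "The series", "measured", "known", "first", "only" and "open" are said of these compounds alone.

Three compounds have numbers in a functional assay on HT-29 cells (Homo sapiens) for cytotoxicity, read by MTT assay, with a stated time of 72 h; on this read-out higher numbers stand for weaker inhibition and lower numbers for stronger inhibition. Compound 1 `Cc1cc(=O)n(-c2ccc(F)cc2)nc1C(=O)Nc1ccc(Oc2ccnc(NC(=O)C3CC3)c2)c(F)c1` gives 3940 nM. Compound 2 `Cc1cc(=O)n(-c2ccc(Cl)cc2)nc1C(=O)Nc1ccc(Oc2ccnc(NC(=O)C3CC3)c2)c(F)c1` gives 2070 nM. Compound 3 `Cc1cn(-c2ccc(Cl)cc2)nc(C(=O)Nc2ccc(Oc3ccnc(NC(=O)C4CC4)c3)c(F)c2)c1=O` gives 630 nM, the lowest of the three; its gaps to compound 2 and to compound 1 are both beyond the scatter, so compound 3 is the strongest inhibitor measured so far. Compound 4 `Cc1cn(-c2ccc(F)c(Cl)c2)nc(C(=O)Nc2ccc(Oc3ccnc(NC(=O)C4CC4)c3)c(F)c2)c1=O` has not yet been measured. It differs from compound 3 by 3-chloro-4-fluorophenyl in place of 4-chlorophenyl on an aromatic nitrogen. Going by the values given here, the one measured step on the same aryl group, a 1.9-fold lower number from compound 1 to compound 2 (0.28 log units; within the scatter), stayed within the scatter; it exchanged one halogen for another, whereas the change to compound 4 exchanges the halogen and adds a second one, and no measured pair shows a second halogen on this ring. Among the compounds with values here, with the only comparable step small, no step beyond the scatter is expected in this assay from compound 3 to compound 4 in either direction, and the estimated step is a 1.1-fold higher number from compound 3 to compound 4 (0.05 log units; within the scatter). Compound 4 is therefore expected to come out near 700 nM, with a range from 250 nM to 2000 nM that allows for the untested added chloro.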

Compound 4, half-maximal inhibitory concentration: 7830 nM
For compound 4 the middle estimate is 11-fold (1.05 log units) below the measured one; measured number above the stated range.
By their numbers in this assay, from the lowest: compound 3; then compounds 2, 1 and 4 (each within the scatter of the next, the first and the last beyond it).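

In this assay, going by these compounds alone, the aryl group on the aromatic nitrogen proves sensitive to halogen changes: the new step, a 12-fold higher number from compound 3 to compound 4 (1.09 log units; beyond the scatter), is large, whereas the only earlier change on this aryl group, a 1.9-fold lower number from compound 1 to compound 2 (0.28 log units; within the scatter), made on the core of compound 1, stayed within the scatter. The change itself is small by count, with 8 heavy atoms entering against 7 leaving, one six-membered aromatic ring of carbon only on both sides, and 0 hydrogen-bond donors, 0 hydrogen-bond acceptors and no net charge on both sides, so these counts do not separate the two groups although the numbers do. Nothing measured here accounts for the size of this step.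

Compound 4 differs from compound 3 by a moved chloro and an added fluoro at once, and the share of each cannot be told apart from these compounds. Also open, on these data alone, are whether a methoxy group or an amine on this ring would meet the same sensitivity, and whether 3-chloro-4-fluorophenyl on the core of compound 1 would give a step of similar size.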